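The compounds below may be only part of what the source reports. "The series", "measured", "known", "first", "only" and "open" are said of these compounds alone.

Working notes on the series.

Compound 1 `Cn1c(SCC(=O)Nn2c(COc3ccc(Cl)cc3Cl)nc3ccccc3c2=O)nc(-c2ccccc2)c(C#N)c1=O` is the simplest member of the set. In a functional assay on the whole organism (strain albino) for inhibition, with Rattus norvegicus as the target, read by paw edema, with stated times of 1 h and 3 h, at a dose of 100 mg/kg by the oral route (a higher number here means a stronger effect of the compound at the dose given, a lower number a weaker effect), compound 1 gives 59.7%. Compound 2 `Cn1c(SCC(=O)Nn2c(COc3ccc(Cl)cc3Cl)nc3ccccc3c2=O)nc(-c2ccc(Cl)cc2)c(C#N)c1=O` carries the change chloro in place of hydrogen on an aromatic carbon relative to compound 1, and in this assay compound 2 gives 73.7%. The resulting step is a number 14 percentage points higher from compound 1 to compound 2 (beyond the scatter).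

Compound 3 `N#Cc1c(Nc2ccccc2)nc(SCC(=O)Nn2c(COc3ccc(Cl)cc3Cl)nc3ccccc3c2=O)nc1-c1ccccc1` has a different core; how its core differs from that of compound 1 is not broken down here. In this assay compound 3 gives 78.1%, which is within the scatter of compound 2 and beyond the scatter above compound 1.

Compound 4 `N#Cc1c(Nc2ccc(Cl)cc2)nc(SCC(=O)Nn2c(COc3ccc(Cl)cc3Cl)nc3ccccc3c2=O)nc1-c1ccccc1` is not yet measured. It differs from compound 3 by chloro in place of hydrogen on an aromatic carbon, the same change that separates compound 2 from compound 1, both at a carbon that is para to a large group, though here, read one bond further out, it is anilino becoming (4-chlorophenyl)amino rather than phenyl becoming 4-chlorophenyl. The expectation for compound 4 rests on the earlier step of a number 14 percentage points higher from compound 1 to compound 2 (beyond the scatter) applied to the value of compound 3, 78.1%, with the upper range of a percentage read-out leaving less room for a gain of the same size. An expected step of a number 6.9 percentage points higher from compound 3 to compound 4 (within the scatter) is therefore assumed. Compound 4 is estimated at 85% in this assay, with a range from 72% to 95%.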

Compound 4, a percentage reported as inhibition, in the whole organism at one dose (the size of the read-out at that dose, not a potency): 59.7%
Estimate against measurement, compound 4: 25.3 percentage points above, outside the stated range (below it).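

In this assay, chloro in place of hydrogen on an aromatic carbon now gives a number 18.4 percentage points lower from compound 3 to compound 4 (beyond the scatter), so a gain seen on one core does not carry over to the other, even in direction. Set side by side, the two steps point opposite ways and their gap is larger than scatter alone would account for: the same change on two cores in this assay, a number 14 percentage points higher (beyond the scatter) from compound 1 to compound 2 and a number 18.4 percentage points lower (beyond the scatter) from compound 3 to compound 4, 32.4 percentage points apart, beyond the scatter of two such steps

This does not show what sets the two results apart, since the chloro enters the phenyl of compound 1 but the anilino of compound 3, and a difference of core cannot be separated from a difference of site with one pair for each; it also rests on a single oral dose and a single read-out, so it gives no rule for other groups or other doses.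

The compounds shown leave open whether chloro on the phenyl of compound 3, with the anilino left unchanged, would rise or fall. They also leave open whether fluoro, methyl or methoxy at the carbon that carries the chloro in compound 4 would follow the same course, or whether a simple alkylamine in place of the anilino would change the picture.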